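The source may hold more compounds than are shown below. What is called first, only, known or untested is meant among the compounds shown, and "the series" means these compounds.

Compound 1 `CCOc1ccc(-c2ccccc2)cc1`, tested in an assay on COS-7 cells for inhibition of patatin-like phospholipase domain-containing protein 2 (Mus musculus); a higher number here means a weaker inhibitor, a lower number a stronger inhibitor: for compound 1 this assay reports only a limit, > 200000 nM, not a number.
Compound 2 `CCOc1ccc(-c2cccc(C)c2)cc1`: in this assay compound 2 gives 70000 nM.
Compound 3 `CCCCOC(=O)c1cccc(-c2ccc(OCC)cc2)c1`: in this assay compound 3 gives 100000 nM.

Among the two numbers, compound 3 holds the higher one; its nearest neighbour is compound 2, and the gap a 1.4-fold higher number from compound 2 to compound 3 (0.15 log units; within the scatter) lies within the scatter, so the two cannot be ranked. Compound 4 `CCOc1ccc(-c2cccc([N+](=O)[O-])c2)cc1` differs from compound 3 by nitro in place of butoxycarbonyl on an aromatic carbon. Among the compounds with values here, only one measured step swaps one substituent for another at this position, a 1.4-fold higher number from compound 2 to compound 3 (0.15 log units; within the scatter), and it stays within the scatter. The two steps that place a group where hydrogen stood, an at least 2.8-fold lower number from compound 1 to compound 2 (0.45 log units; beyond the scatter) and an at least 2.0-fold lower number from compound 1 to compound 3 (0.30 log units; that floor lies within the scatter), both start from the limit of > 200000 nM in this assay, at which 1 of the 3 values shown sits, and therefore give only floors, not sizes. Within the data shown here, no measured compound carries a nitro group, so nothing in the data speaks to the entering group itself. On this basis the step of no change at the digits printed from compound 3 to compound 4 (within the scatter) is expected to be small, with no direction that can be called beyond the scatter. Compound 4 is estimated at 100000 nM, within a range from 30000 nM to 300000 nM.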

Compound 4, half-maximal inhibitory concentration: > 200000 nM
Compound 4: no number, only a limit; the forecaster's own chance of this, stated with the estimate: 35%; at least 2.0-fold (0.30 log units) between middle value and limit.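

Compound 4 gives only a limit in this assay, > 200000 nM, not a number, whereas the methyl and butoxycarbonyl groups at this position both gave numbers. Replacing butoxycarbonyl with nitro gives an at least 2.0-fold higher number from compound 3 to compound 4 (0.30 log units; that floor lies within the scatter), while replacing methyl with nitro gives an at least 2.8-fold higher number from compound 2 to compound 4 (0.45 log units; beyond the scatter), so the choice of group here now produces a separation beyond the scatter, which the swap between methyl and butoxycarbonyl did not. The step between compound 1 and compound 4 cannot be read, because both compounds stand at the limit of the assay: the limit of > 200000 nM in this assay, at which 2 of the 4 values shown sit.

Going by these compounds, how far compound 4 lies past its limit remains open, and so does whether nitro differs at all from the hydrogen of compound 1 at this position. Also open, on these data alone, is whether an amine, a carboxylic acid or a methyl ester on this aromatic carbon would give a number like those of compound 2 and compound 3 or a limit like that of compound 4.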